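This account rests on a few compounds, and the source may have more. Where it says the series, first, only, none or still open, it means among the compounds named here.

Series notes. Compound 1 `CCC(C)C(NC(=O)n1nnc2ccccc21)C(=O)NC(c1ccccc1)c1ccccc1` gives 63500 nM in a functional assay on SW-620 cells (Homo sapiens) for inhibition; on this read-out higher numbers stand for weaker inhibition and lower numbers for stronger inhibition. For compound 2 `CCC(C)C(NC(=O)NO)C(=O)NCc1ccccc1` this assay reports only a limit, > 100000 nM. Compound 2 thus stands at the limit of > 100000 nM in this assay, at which 1 of the 2 values shown sits, and no number is known for it. Compound 3 `CCC(C)C(NC(=O)n1nnc2ccccc21)C(=O)NCc1ccccc1` is not yet measured. Relative to compound 2 the change is a group of 9 heavy atoms (6 carbon, 3 nitrogen; one five-membered aromatic ring with 3 hetero atoms, one six-membered aromatic ring of carbon only) in place of a group of 2 heavy atoms (1 nitrogen, 1 oxygen; no ring), on a carbonyl carbon. With compound 2 at a limit, the size of the step is not fixed by the data. Compound 1 carries the same entering group and shows only weak inhibition at 63500 nM. A modest step toward stronger inhibition is expected, an at least 1.4-fold lower number from compound 2 to compound 3 (0.15 log units; that floor lies within the scatter). Compound 3 is estimated at 70000 nM, within 25000 nM to 200000 nM.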

Compound 3, half-maximal inhibitory concentration: > 100000 nM
Compound 3 was reported as a limit; the forecaster's own chance of this, stated with the estimate: 40%; middle value at least 1.4-fold (0.15 log units) from the limit.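

The step on the carbonyl carbon, with the hydroxyamino group replaced, cannot be read, because compound 2 and compound 3 both sit at a limit: the limit of > 100000 nM in this assay, at which 2 of the 3 values shown sit.

On the other side of compound 3, hydrogen in place of phenyl gives an at least 1.5-fold higher number from compound 1 to compound 3 (0.19 log units; that floor lies within the scatter), so this comparison shows no loss beyond the scatter.

Still open, going by these compounds, is how a simple amine or a carboxylic acid on the carbonyl carbon would read, and whether a cyclohexyl group in place of phenyl on the saturated chain carbon would give a number rather than a limit.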